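Diarylamine ethers: amine swap on the benzylic carbon

The compounds below may be only part of what the source reports. "The series", "measured", "known", "first", "only" and "open" are said of these compounds alone.

Three measured members of the series carry the shared diphenylamine ether core with a substituted benzylic amine. Compound 1 `COc1ccc(CCCNCc2c(OC)cc(Oc3ccc(Nc4ccccc4)cc3)cc2OC)cc1` gives 4650 nM in a functional assay on DLD-1 cells (Homo sapiens) for inhibition, read by MTT assay, with a stated time of 72 h (on this read-out higher numbers stand for weaker inhibition and lower numbers for stronger inhibition), compound 2 `COc1cc(Oc2cccc(Nc3ccccc3)c2)cc(OC)c1CNCCNC(C)=O` gives 6010 nM in this assay, and compound 3 `COc1ccc([C@@H](C)NCc2c(OC)cc(Oc3cccc(Nc4ccccc4)c3)c(OC)c2OC)cc1` gives 3500 nM in this assay. Compound 2 shows the highest of the three numbers, yet its gaps to compound 1 and to compound 3 both sit within the scatter of repeated measurements, so the three values cannot be ranked against one another.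

Going by the values given here, no pair among the measured compounds differs in one place only, so no measured single step is available to calibrate the next change. Compound 4 `CCN1CCN(Cc2c(OC)cc(Oc3cccc(Nc4ccccc4)c3)cc2OC)CC1` is the next member to be measured in this assay. It differs from compound 2 by 4-ethylpiperazin-1-yl in place of (2-acetamidoethyl)amino on a saturated chain carbon bound to an aromatic carbon. With no measured step of this kind in hand, the expectation rests on the narrow spread of the three values already seen, and the change is expected to move the number by no more than a small step, if at all beyond the scatter, toward a somewhat lower value. The expected step is a 1.3-fold lower number from compound 2 to compound 4 (0.13 log units; within the scatter). For compound 4 the estimated value in this assay is 4500 nM, with a range from 1500 nM to 13000 nM.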

Compound 4, half-maximal inhibitory concentration: > 20000 nM
Compound 4 ended at the assay's limit (the forecaster's own chance of this, stated with the estimate: 5%); middle value at least 4.4-fold (0.64 log units) from the limit.
By their numbers in this assay, from the lowest: compounds 3, 1 and 2 (each within the scatter of the next). At a limit, above all of these: compound 4.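

In this assay, going by these compounds alone, the amine on the saturated chain carbon bound to an aromatic carbon proves able to shift the read-out: the swap gives an at least 3.3-fold higher number from compound 2 to compound 4 (0.52 log units; beyond the scatter), the only step so far and one that lies beyond the scatter. Compound 4 gives > 20000 nM, which is a limit of the assay and not a number: the limit of > 20000 nM in this assay, at which 1 of the 4 values shown sits. The change replaces a ring-free (2-acetamidoethyl)amino group, with a double bond outside aromatic rings and hydrogen-bond donors, by 4-ethylpiperazin-1-yl, a six-membered non-aromatic ring with no hydrogen-bond donors, so this single step shows that the position does not accept every amine alike in this assay.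

Several features change together in this one step, and the compounds shown do not separate the ring, the loss of the acetamide carbonyl and the loss of the hydrogen-bond donors from one another. A morpholin-4-yl ring, an open-chain diethylamino group or a piperazine carrying an acetyl group in place of the ethyl group on the same carbon would help to tell these apart.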